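Replacing the aryl arm with fluorine on a tetrazole acetamide

The compounds below may be only part of what the source reports. "The series", "measured", "known", "first", "only" and "open" are said of these compounds alone.

Measured compounds:
Compound 1 `CCCCCCCCCCCCn1nnc(C(C(=O)Nc2c(OC)cc(OC)cc2OC)c2ccc(OC)cc2)n1` in an assay on liver for inhibition of sterol O-acyltransferase 1 (Rattus norvegicus), using microsomes (on this read-out lower numbers stand for stronger inhibition and higher numbers for weaker inhibition), gives 200 nM.
Compound 2 `CCCCCCCCCCCCn1nnc(C(C(=O)Nc2c(OC)cc(OC)cc2OC)c2ccc(N(C)C)cc2)n1` gives 659 nM.
Compound 3 `CCCCCCCCCCCCn1nnc(C(C(=O)Nc2c(OC)cc(OC)cc2OC)c2ccc(-c3ccccc3)cc2)n1` gives 221 nM.

Compound 3 sits in the middle of these three numbers. Its nearest neighbour is compound 1, with a 1.1-fold higher number from compound 1 to compound 3 (0.04 log units; within the scatter), a difference too small to mean anything. Against compound 2 there is a 3.0-fold lower number from compound 2 to compound 3 (0.47 log units; beyond the scatter), a modest but real gap.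

Compound 4 `CCCCCCCCCCCCn1nnc(C(F)C(=O)Nc2c(OC)cc(OC)cc2OC)n1` is a different kind of change. The step is fluoro in place of 4-phenylphenyl on a saturated chain carbon bound to an aromatic carbon and a carbonyl carbon. All three measured steps only swapped one group on the far end of the aromatic ring that is now removed altogether: a 3.3-fold higher number from compound 1 to compound 2 (0.52 log units; beyond the scatter) and a 3.0-fold lower number from compound 2 to compound 3 (0.47 log units; beyond the scatter) were modest, and a 1.1-fold higher number from compound 1 to compound 3 (0.04 log units; within the scatter) was within the scatter. None of them tells what happens when the whole 4-phenylphenyl is taken away and a single fluorine stands in its place, so the expectation rests on judgement alone. A loss of much of the compound is expected to show as a clearly higher number, so the step is estimated at a 14-fold higher number from compound 3 to compound 4 (1.13 log units; beyond the scatter). Compound 4 is therefore expected to give about 3000 nM, with a wide range from 500 nM to 30000 nM.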

Compound 4, half-maximal inhibitory concentration: 1760 nM
Estimate against measurement, compound 4: 1.7-fold (0.23 log units) above; measured number inside the range.
By their numbers in this assay, from the lowest: compounds 1 and 3 (each within the scatter of the next); then compound 2; then compound 4.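

The aryl arm on this saturated chain carbon counts for more than the groups at its far end, whose swaps moved the number less in this assay than removing the arm altogether. Putting a single fluorine in place of the arm gives an 8.0-fold higher number from compound 3 to compound 4 (0.90 log units; beyond the scatter) and an 8.8-fold higher number from compound 1 to compound 4 (0.94 log units; beyond the scatter), while the same kind of change starting from the 4-(dimethylamino)phenyl compound gives the smaller 2.7-fold higher number from compound 2 to compound 4 (0.43 log units; beyond the scatter), so the size of the loss depends on which arm is replaced. All three steps lie beyond the scatter and make compound 4 the weakest of the four, yet with 1760 nM compound 4 still gives a measured number, so inhibition in this series does not vanish when the arm, with its 12 heavy atoms, is gone.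

The compounds shown leave open whether a hydrogen, a methyl or a plain phenyl on this carbon would fall nearer to compound 4 or to compound 1, so the loss of the arm cannot yet be separated from any contribution of the fluorine itself. What lies behind the loss also stays open, since no measurement at hand bears on it.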